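The source may hold more compounds than are shown below. What is called first, only, known or untested is meant among the compounds shown, and "the series" means these compounds.

Compound 1, `Cc1ccc(Nc2ncc(Cl)c(Nc3ccccc3C)n2)cc1`: in a functional assay on MCF7 cells (Homo sapiens) for inhibition, read by CCK-8 assay, with a stated time of 48 h (a lower number here means a stronger inhibitor of growth, a higher number a weaker inhibitor of growth), compound 1 gives only a limit of the assay, > 100000 nM.
Compound 2, `CCN1CCN(c2ccc(Nc3ncc(Cl)c(Nc4ccccc4C)n3)nc2)CC1`: compound 2 likewise reaches only a limit, > 100000 nM.
Compound 3, `CN1CCN(c2ccc(Nc3ncc(Cl)c(NCc4ccc(F)cc4)n3)nc2)CC1`: compound 3 gives 19300 nM.

For the measured compounds named here, compound 3 therefore holds the only number among the three; the other two values sit at the limit of > 100000 nM in this assay, at which 2 of the 3 values shown sit. Compound 4, `COc1cccc(Nc2nc(Nc3ccc(N4CCN(C)CC4)cn3)ncc2Cl)c1`, is still to be measured in this assay. It differs from compound 3 in one place: 3-methoxyphenyl in place of 4-fluorobenzyl on a nitrogen on an aromatic ring. Compound 4 resembles compound 2 more closely than compound 3 does, and compound 2 reached only a limit, so a step toward weaker growth inhibition, beyond the usual scatter, is expected, a 2.6-fold higher number from compound 3 to compound 4 (0.41 log units; beyond the scatter). Compound 4 is estimated at 50000 nM, with a range from 10000 nM to 150000 nM.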

Compound 4, concentration for 50% growth inhibition: 7540 nM
Beside the measured number, compound 4's estimate is 6.6-fold (0.82 log units) above it; measured number below the stated range.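

At the nitrogen on an aromatic ring, in this assay, 3-methoxyphenyl in place of 4-fluorobenzyl gives a 2.6-fold lower number from compound 3 to compound 4 (0.41 log units; beyond the scatter), the first readable effect of a change at this position. The earlier compounds shown here offered no such comparison, as most of their values stood at a limit: the limit of > 100000 nM in this assay, at which 2 of the 4 values shown sit. The compounds shown leave open how a plain phenyl, a 4-methoxyphenyl or a 3-methoxybenzyl group would read at this nitrogen. The loss of the benzyl carbon therefore cannot be separated from the exchange of fluorine for methoxy.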